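Para-bromo on the benzoyl hydrazide: cytotoxicity outlook

The source may hold more compounds than are shown below. What is called first, only, known or untested is meant among the compounds shown, and "the series" means these compounds.

Compound 1 `CC1(C)[C@@H]2CC[C@@]1(C)/C(=N/NC(=O)C(F)(F)F)C2` and compound 2 `CC1(C)[C@@H]2CC[C@@]1(C)/C(=N/NC(=O)c1ccccc1)C2` share one core. In an ADME assay on Vero cells (Chlorocebus sabaeus) for cytotoxicity, read by spectrophotometry, with a stated time of 4 days (on this read-out lower numbers stand for higher toxicity in this test and higher numbers for lower toxicity in this test), compound 1 gives only a limit, > 250000 nM. In this assay compound 2 gives 1430000 nM, the only number shown so far. The step that the limit leaves unreadable from compound 1 to compound 2 cannot be sized because of the limit of > 250000 nM in this assay, at which 1 of the 2 values shown sits. Compound 3 `CC1(C)[C@@H]2CC[C@@]1(C)/C(=N/NC(=O)c1ccc(Br)cc1)C2` carries bromo in place of hydrogen on an aromatic carbon, para to a large group. Going by the values given here, no measured step bears on this change, so the expectation rests on compound 2 alone. The step from compound 2 to compound 3 is expected to be a 1.8-fold lower number from compound 2 to compound 3 (0.25 log units; within the scatter), within scatter. Compound 3 is estimated at 800000 nM, with a range from 200000 nM to 2500000 nM.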

Compound 3, half-maximal cytotoxic concentration: 288000 nM
Compound 3: middle estimate off by 2.8-fold (0.44 log units), on the high side; the measured number falls inside the stated range.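

In this assay, bromo in place of hydrogen on an aromatic carbon, para to a large group, gives a 5.0-fold lower number from compound 2 to compound 3 (0.70 log units; beyond the scatter). Going by these compounds alone, this is the first readable step, and it shows that this position can shift the read-out towards higher toxicity in this test. The step from compound 1 cannot be read, because compound 1 gives only a limit: the limit of > 250000 nM in this assay, at which 1 of the 3 values shown sits.

From the compounds shown here alone, it stays open whether an amine or a carboxylic acid at this same place would move the number in the same direction. Going by these compounds, the effect of chloro there also remains open.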